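This account rests on a few compounds, and the source may have more. Where it says the series, first, only, none or still open, it means among the compounds named here.

Compound 1 `COc1cc([C@@H]2C[C@@]2(CO)C(=O)Nc2ccccc2)cc(OC)c1OC` gives in a functional assay on K562 cells (Homo sapiens) for cytotoxicity, read by MTT assay, with a stated time of 48 h (a higher number here means a weaker inhibitor, a lower number a stronger inhibitor), only a limit of the assay, > 100000 nM.
Compound 2 `CCOC(=O)[C@@]1(C(=O)Nc2ccccc2Cl)C[C@H]1c1cc(OC)c(OC)c(OC)c1` likewise gives in this assay only a limit, > 100000 nM.
Compound 3 `COc1cc([C@@H]2C[C@@]2(CO)C(=O)Nc2ccccc2Cl)cc(OC)c1OC` gives in this assay a number, 18400 nM.

Two changes separate these compounds. The first, (hydrogen in place of chloro on an aromatic carbon), produced an at least 5.4-fold higher number from compound 3 to compound 1 (0.73 log units; beyond the scatter), and its size is bounded because the limit of > 100000 nM in this assay, at which 2 of the 3 values shown sit, caps what can be seen. The second sets the two cores apart: ethoxycarbonyl in place of hydroxymethyl on a saturated ring carbon, which produced an at least 5.4-fold lower number from compound 2 to compound 3 (0.73 log units; beyond the scatter).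

Compound 4 `CCOC(=O)[C@@]1(C(=O)Nc2ccccc2)C[C@H]1c1cc(OC)c(OC)c(OC)c1` has not been measured. It differs from compound 2 by hydrogen in place of chloro on an aromatic carbon, the same change that was made from compound 3 to compound 1. Since compound 2 already sits at the limit, its estimate is a step that the limit leaves unreadable from compound 2 to compound 4, resting on the direction of an at least 5.4-fold higher number from compound 3 to compound 1 (0.73 log units; beyond the scatter). Compound 4 is therefore expected to read about 200000 nM, between 80000 nM and 600000 nM, most likely again as a limit.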

Compound 4, half-maximal inhibitory concentration: > 100000 nM
Compound 4: a limit, no number; the forecaster's own chance of this, stated with the estimate: 85%; the middle value is on the limit's open side.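

Compound 4 gives only a limit in this assay, so no new step can be read from compound 1 or compound 2 to compound 4: the limit of > 100000 nM in this assay, at which 3 of the 4 values shown sit.

From the compounds shown here alone, whether chloro changes the reading among the ethoxycarbonyl compounds, as it does between compound 1 and compound 3, stays open.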